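Cyclohexylamino in place of anilino: cytotoxicity on Vero cells

The source may report more compounds than this note shows. Statements on the series, on what has been measured and on what is new or still open speak of the compounds shown alone.

Measured compounds:
compound 1, `O=c1nc(NCc2ccc(F)cc2)oc2c([N+](=O)[O-])cc(C(F)(F)F)cc12`: > 64 ug/mL
compound 2, `O=c1cc(Nc2ccccc2)sc2c([N+](=O)[O-])cc(C(F)(F)F)cc12`: > 64 ug/mL

In an ADME assay on Vero cells (Chlorocebus sabaeus) for cytotoxicity, read by MTT assay, with a stated time of 48 h (a higher number here means a weaker inhibitor, a lower number a stronger inhibitor), compound 1 gives > 64 ug/mL, which is a limit of the assay. In this assay, among the measured compounds shown here, compound 2 gives > 64 ug/mL, also a limit, so compound 2 sits at the same edge as the only other value shown, (the limit of > 64 ug/mL in this assay, at which 2 of the 2 values shown sit). Compound 3, `O=c1cc(NC2CCCCC2)sc2c([N+](=O)[O-])cc(C(F)(F)F)cc12`, differs from compound 2 by cyclohexyl in place of phenyl on a nitrogen on an aromatic ring. For the measured compounds named here, with no measured step available, the step from compound 2 to compound 3 is expected to be none beyond the scatter, a step that the limit leaves unreadable from compound 2 to compound 3. Compound 3 is therefore estimated at 80 ug/mL, with a range from 30 ug/mL to 200 ug/mL.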

Compound 3, half-maximal inhibitory concentration: > 64 ug/mL
Compound 3: no number, only a limit; the forecaster's own chance of this, stated with the estimate: 75%; the middle value lies beyond the limit too.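

In this assay, compound 2 and compound 3 both stand at a limit of the assay, so no step can be read between them: the limit of > 64 ug/mL in this assay, at which 3 of the 3 values shown sit.

Whether cyclohexyl in place of phenyl alters cytotoxicity at all, and where any of these compounds reaches half-maximal inhibition, stays open.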